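Methyl in place of trifluoromethyl on compound 1

The source may hold more compounds than are shown below. What is called first, only, known or untested is meant among the compounds shown, and "the series" means these compounds.

Measured in an ADME assay on Vero cells (Chlorocebus sabaeus) for inhibition, read by MTT assay, with a stated time of 72 h; a higher number here means a weaker inhibitor, a lower number a stronger inhibitor; each entry is a limit of the assay and not a number:
- compound 1 `O=C(O)CCCCCCC(=O)Nc1ccc(C2=C(c3ccc(O)cc3)C3CC(S(=O)(=O)Oc4ccccc4C(F)(F)F)C2O3)cc1`: > 100000 nM
- compound 2 `O=S(=O)(Oc1ccccc1)[C@H]1C[C@H]2O[C@@H]1C(c1ccc(O)cc1)=C2c1ccc(O)cc1`: > 100000 nM
- compound 3 `COC(=O)CCCCCCC(=O)Nc1cccc(OS(=O)(=O)C2CC3OC2C(c2ccc(O)cc2)=C3c2ccc(O)cc2)c1`: > 100000 nM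

Compound 1 stands at a limit, and so do the other two entries, giving the limit of > 100000 nM in this assay, at which 3 of the 3 values shown sit, as the whole picture. Compound 4 `Cc1ccccc1OS(=O)(=O)C1CC2OC1C(c1ccc(NC(=O)CCCCCCC(=O)O)cc1)=C2c1ccc(O)cc1` carries methyl in place of trifluoromethyl on an aromatic carbon. For the measured compounds named here, no measured pair isolates this change. No step beyond the scatter is expected in this assay, in either direction, and a further limit is the likeliest result. That expectation rests on compound 1 at its limit of > 100000 nM and on nothing finer. The expected change is a number no higher from compound 1 to compound 4 (the limit leaves the size open). Compound 4 is estimated at 100000 nM, with an expected range from 50000 nM to 200000 nM.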

Compound 4, half-maximal inhibitory concentration: > 100000 nM
Compound 4: only a limit was reported; the forecaster's own chance of this, stated with the estimate: 85%; the middle value lies on the limit itself.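

In this assay, compound 1 and compound 4 both stand at a limit, so no step can be read between them: the limit of > 100000 nM in this assay, at which 4 of the 4 values shown sit.

The compounds shown leave open what this assay would read for any of them as an actual number, and so whether methyl in place of trifluoromethyl changes inhibition at all.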